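Shortening the amine-bearing chain on a thienopyrimidine urea

This account rests on a few compounds, and the source may have more. Where it says the series, first, only, none or still open, it means among the compounds named here.

Two compounds share one core and differ at a single point. Compound 1 `CCN(CC)CCCNc1nc(-c2ccc(NC(=O)Nc3ccccc3)cc2)nc2c(Cl)c(Cl)sc12` carries a plain phenyl on the urea; in a functional assay on NCI-H460 cells (Homo sapiens) for cytotoxicity, read by MTT assay, with a stated time of 72 h (a higher number here means a weaker inhibitor, a lower number a stronger inhibitor), compound 1 gives 850 nM. Compound 2 `CCN(CC)CCCNc1nc(-c2ccc(NC(=O)Nc3ccccc3Cl)cc2)nc2c(Cl)c(Cl)sc12` has a chloro in place of hydrogen on that aromatic carbon, and in this assay compound 2 gives 330 nM. Going by the values given here, that single change produced a 2.6-fold lower number from compound 1 to compound 2 (0.41 log units; beyond the scatter), so compound 2 stands with the lowest of the two numbers so far.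

Compound 3 `CCN(CC)CCNc1nc(-c2ccc(NC(=O)Nc3ccccc3Cl)cc2)nc2c(Cl)c(Cl)sc12` keeps the chlorinated urea of compound 2 and alters the other end of the molecule: diethylamino in place of (diethylamino)methyl on a saturated chain carbon, two bonds along the chain from a nitrogen on an aromatic ring. In plainer terms, the 3-(diethylamino)propyl chain becomes a 2-(diethylamino)ethyl chain.

Among the compounds with values here, no measured step touches this chain; the only step available, from compound 1 to compound 2, concerns the urea end and says nothing about chain length. With no guidance, the expectation is a step of no more than the usual scatter in either direction. Compound 3 is therefore estimated at 350 nM, with a range of 120 nM to 1000 nM, meaning an expected step of a 1.1-fold higher number from compound 2 to compound 3 (0.03 log units; within the scatter).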

Compound 3, half-maximal inhibitory concentration: 460 nM
Compound 3: the middle estimate sits 1.3-fold (0.12 log units) below what was measured; the measured number falls inside the stated range.
By their numbers in this assay, from the lowest: compounds 2, 3 and 1 (each within the scatter of the next, the first and the last beyond it).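

Replacing the 3-(diethylamino)propyl chain with the 2-(diethylamino)ethyl chain gives a 1.4-fold higher number from compound 2 to compound 3 (0.14 log units; within the scatter) in this assay, so this pair does not separate the two chain lengths. Going by these compounds alone, this is the first reading at the amine-bearing end of the molecule, as the earlier step concerned only the urea end: with the chlorinated urea and the terminal diethylamino group held constant, removing one saturated chain carbon leaves the number within the usual variation between repeat measurements. No independent measurement is available to explain this result.

The compounds shown leave open whether a longer chain, such as 4-(diethylamino)butyl, or a different terminal amine, such as pyrrolidine or morpholine in place of diethylamino, would move the number beyond the scatter. They also leave open whether the 2-(diethylamino)ethyl chain would read the same way alongside the plain phenyl urea of compound 1, as both chain lengths appear here only with the chlorinated urea.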